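From 3,5-dichlorophenyl to 3-cyanophenyl on the shared core

The source may hold more compounds than are shown below. What is called first, only, known or untested is meant among the compounds shown, and "the series" means these compounds.

Of the compounds shown here, three on the shared core have been measured in an ADME assay (liver) for metabolic stability, with Liver microsome (Homo sapiens) as the target, read by LC-MS, using microsomes, with a stated time of 1 h, tested at 5 uM; a lower number here means that less of the compound is left, a higher number that more of the compound is left. Compound 1 `Cc1ccc(C)c(N2CCN(C(=O)c3oc(C)nc3-c3ccccc3)CC2)c1` gives 33.8% and compound 2 `Cc1cc(C)cc(N2CCN(C(=O)c3oc(C)nc3-c3ccccc3)CC2)c1` gives 25.6%. Compound 3 `Cc1nc(-c2ccccc2)c(C(=O)N2CCN(c3cc(Cl)cc(Cl)c3)CC2)o1` stands highest of the three at 66.3%.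

Compound 4 `Cc1nc(-c2ccccc2)c(C(=O)N2CCN(c3cccc(C#N)c3)CC2)o1` is the next to be read: 3-cyanophenyl in place of 3,5-dichlorophenyl on an amine nitrogen in a ring. It carries 3-cyanophenyl in place of 3,5-dichlorophenyl on an amine nitrogen in a ring.

All measured steps are changes at this same place. The step of a number 8.2 percentage points lower from compound 1 to compound 2 (within the scatter) is within the scatter. The steps of a number 32.5 percentage points higher from compound 1 to compound 3 (beyond the scatter) and a number 40.7 percentage points higher from compound 2 to compound 3 (beyond the scatter) are both large, and each brings in the 3,5-dichlorophenyl group. Removing that group may therefore give back part of this gain, so the direction expected is downward. Among the compounds with values here, no measured compound carries a nitrile, and the data do not show how much of the gain would be lost. A return all the way to the level of compound 2 at 25.6% is not assumed. The expected change is a moderate drop, smaller than the two large steps: a number 16.3 percentage points lower from compound 3 to compound 4 (beyond the scatter). Compound 4 is estimated at 50%, with an expected range from 30% to 70%.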

Compound 4, percent of the compound remaining: 8%
Compound 4: middle estimate off by 42 percentage points, on the high side, outside the stated range (below it).
By their numbers in this assay, from the lowest: compound 4; then compounds 2 and 1 (each within the scatter of the next); then compound 3.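

In this assay, within the data shown here, this position on an amine nitrogen in a ring moves the number further than the earlier compounds showed: the step of a number 58.3 percentage points lower from compound 3 to compound 4 (beyond the scatter) is larger than any step seen before at this place. Compound 4 also lies under both dimethylphenyl compounds, with the steps of a number 17.6 percentage points lower from compound 2 to compound 4 (beyond the scatter) and a number 25.8 percentage points lower from compound 1 to compound 4 (beyond the scatter), so replacing 3,5-dichlorophenyl here does not simply return the number to the level of those compounds, and 3-cyanophenyl gives the lowest number of the four. The 3,5-dichlorophenyl and 3-cyanophenyl groups have the same heavy-atom count, so that count does not separate compound 3 from compound 4.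

No information at hand accounts for the size or direction of this drop. Going by these compounds, it remains open whether the low number goes with the nitrile itself or with the loss of both chlorines, a question that a plain phenyl group or a monochlorophenyl group at this place could help to separate.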